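Aryl Swap on a Ring Nitrogen: Compound 2 to Compound 3

This account rests on a few compounds, and the source may have more. Where it says the series, first, only, none or still open, it means among the compounds named here.

Compound 1 `Cc1ccc(N2CCN(CC(=O)Nc3nc4c(s3)CCCC4)CC2)cc1`: 250 nM
Compound 2 `O=C(CN1CCN(c2nccs2)CC1)Nc1nc2c(s1)CCCC2`: 520 nM

In an assay on isolated protein for inhibition of long-chain fatty acid transport protein 1 (Homo sapiens), read by scintillation counting, with a stated time of 20 min (on this read-out lower numbers stand for stronger inhibition and higher numbers for weaker inhibition), compound 2 gives 520 nM, the higher of the two numbers measured, while compound 1 gives 250 nM. Within the data shown here, the single measured step is a 2.1-fold higher number from compound 1 to compound 2 (0.32 log units; beyond the scatter). Compound 3 `O=C(CN1CCN(c2cccnc2)CC1)Nc1nc2c(s1)CCCC2` carries the change (pyridin-3-yl in place of 1,3-thiazol-2-yl on an amine nitrogen in a ring). That earlier step changed a group at the same ring nitrogen, so it bears on this one only loosely, and the direction it suggests is small. Compound 3 is therefore expected to land near compound 2, estimated at 400 nM with a range from 150 nM to 1100 nM. This estimate amounts to a 1.3-fold lower number from compound 2 to compound 3 (0.11 log units; within the scatter), within the usual scatter.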

Compound 3, half-maximal inhibitory concentration: > 1000 nM
Compound 3: a limit, no number (the forecaster's own chance of this, stated with the estimate: 5%); middle value at least 2.5-fold (0.39 log units) away from the limit.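

In this assay compound 3 gives a limit, not a number: the limit of > 1000 nM in this assay, at which 1 of the 3 values shown sits. Pyridin-3-yl in place of 4-methylphenyl on this ring nitrogen gives an at least 4.0-fold higher number from compound 1 to compound 3 (0.60 log units; beyond the scatter), so the position does not tolerate every six-membered aromatic ring equally. Pyridin-3-yl in place of 1,3-thiazol-2-yl gives an at least 1.9-fold higher number from compound 2 to compound 3 (0.28 log units; that floor lies within the scatter), so this step alone does not separate the two compounds.

As far as these compounds go, the true value of compound 3 remains open. So does how an unsubstituted phenyl or a pyridin-4-yl on this ring nitrogen would read against compound 1.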